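Swapping the aryl group on the sulfonamide nitrogen

This account rests on a few compounds, and the source may have more. Where it says the series, first, only, none or still open, it means among the compounds named here.

Compound 1 `CC(C)CN(c1ccc(N(C)C)cc1)S(=O)(=O)c1ccc2c(c1)C(O)CC(C1CCOCC1)O2` has the lowest of the two values known here in a physicochemical assay for lipophilicity, at pH 7.4; on this read-out higher numbers stand for higher lipophilicity and lower numbers for lower lipophilicity: compound 1 gives 3.51, while compound 2 `CCc1ccc(N(CC(C)C)S(=O)(=O)c2ccc3c(c2)C(OC)CC(C2CCOCC2)O3)cc1` gives 4.69, a gap beyond the usual scatter. Compound 3 `CC(C)CN(c1cc2ccccc2s1)S(=O)(=O)c1ccc2c(c1)C(O)CC(C1CCOCC1)O2` has not yet been measured. It differs from compound 1 by one change: 1-benzothiophen-2-yl in place of 4-(dimethylamino)phenyl on a sulfonamide nitrogen. For this step an upward move beyond the scatter is expected, and in this assay the step from compound 1 to compound 3 is estimated at a number 0.99 log units higher from compound 1 to compound 3 (beyond the scatter), in keeping with where compound 2 stands at 4.69. Compound 3 is therefore expected to reach 4.5, within 3.9 to 5.1.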

Compound 3, distribution coefficient: 3.92
Compound 3: the middle estimate sits 0.58 log units above what was measured; the measured number falls inside the stated range.
By their numbers in this assay, from the lowest: compound 1; then compound 3; then compound 2.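

In this assay, going by these compounds alone, the change of 4-(dimethylamino)phenyl to 1-benzothiophen-2-yl on the sulfonamide nitrogen gives a number 0.41 log units higher from compound 1 to compound 3 (beyond the scatter), the first step here that isolates this position. It shows that the read-out responds to this swap, although the step is modest. Nothing available here accounts for the size of the step.

The compounds shown leave open how a plain phenyl or a pyridinyl group would read on this nitrogen. They also leave open whether the same swap gives a similar step when the rest of the core differs.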